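The compounds below may be only part of what the source reports. "The series", "measured", "known", "first", "only" and "open" are said of these compounds alone.

Working notes on the series. The shared core of compound 1 `COc1ccc([C@@H]2C/C(=N/OCc3cn(-c4ccccc4CO)nn3)c3cc(CC=C(C)C)c(OC)cc3O2)cc1` carries on an aromatic nitrogen of its triazole a 2-(hydroxymethyl)phenyl group. In a functional assay on A549 cells (Homo sapiens) for inhibition, read by sulforhodamine B assay, with a stated time of 48 h, tested at 50 uM (on this read-out lower numbers stand for less inhibition of growth and higher numbers for more inhibition of growth at the one concentration tested), compound 1 gives 100%. Within the data shown here, this is the highest of the three numbers known so far. The nearest is compound 3 `COc1cc2c(cc1CC1OC1(C)C)C(=O)C[C@@H](c1ccc(O)cc1)O2`, which in this assay gives 79%, a gap beyond the scatter. The furthest is compound 2 `COc1ccc([C@@H]2C/C(=N/O)c3cc(CC=C(C)C)c(OC)cc3O2)cc1`, the free oxime without any substituent on the oxime oxygen, which in this assay gives 66%, also beyond the scatter below compound 1.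

Compound 4 `COc1ccc([C@@H]2C/C(=N/OCc3cn(-c4cc(OC)c(OC)c(OC)c4)nn3)c3cc(CC=C(C)C)c(OC)cc3O2)cc1` keeps the core and the triazole linker of compound 1 and differs only in the aryl on the aromatic nitrogen: 3,4,5-trimethoxyphenyl in place of 2-(hydroxymethyl)phenyl on an aromatic nitrogen. Among the measured compounds shown here, no measured pair shows the effect of exchanging one aryl for another on this nitrogen, so the expectation rests on compound 1 alone. Because compound 1 already sits at 100%, the step of a number 8 percentage points lower from compound 1 to compound 4 (within the scatter) is expected to be small and, if anything, downward, within or close to the scatter. Compound 4 is thus estimated at 92% in this assay, with a range from 72% to 100%.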

Compound 4, percent growth inhibition at one concentration: 28%
Beside the measured number, compound 4's estimate is 64 percentage points above it, and the stated range ends above it.
By their numbers in this assay, from the lowest: compound 4; then compound 2; then compound 3; then compound 1.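

Among these compounds, compound 1 and compound 4 form the first measured pair that differs in one place, and it shows that the aryl on an aromatic nitrogen of the five-membered aromatic ring with 3 nitrogen is not a neutral part of the series. In this assay the exchange of 2-(hydroxymethyl)phenyl for 3,4,5-trimethoxyphenyl brings a number 72 percentage points lower from compound 1 to compound 4 (beyond the scatter) and so moves the number far with the core and linker unchanged. No measurement at hand tells which part of this exchange carries the step.

Open, going by these compounds, is whether the step follows the loss of the hydroxymethyl group or the entry of the three methoxy groups, which a plain phenyl, or a phenyl carrying an amine or a carboxylic acid in place of the hydroxymethyl group, could help to separate. Also open, on these data alone, is how compound 1 and compound 4 would rank at concentrations other than the one tested.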